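A halogen swap on the sulfur of compound 2

The source may report more compounds than this note shows. Statements on the series, on what has been measured and on what is new or still open speak of the compounds shown alone.

Of the compounds shown here, three have been read so far in an ADME assay on cells (Homo sapiens) for cytotoxicity, read by resazurin assay, with a stated time of 5 days; a higher number here means that more compound is tolerated, a lower number that less compound is tolerated. Compound 2 (`COc1ccc(-c2nc(CSc3cccc(Cl)c3Cl)nc3ccsc23)cn1`) gives > 50000 nM as a limit of the assay, not a number. Compound 1 (`O=S(=O)(Cc1nc(-c2ccncc2)c2sccc2n1)c1cccc(Cl)c1`) gives > 50000 nM as a limit too. Compound 3 (`O=S(=O)(Cc1nc(-c2ccc(F)nc2)c2sccc2n1)c1cccc(Cl)c1`) gives 40000 nM as a measured number. Compound 2 therefore has no exact place on the scale, and the set as a whole is marked by the limit of > 50000 nM in this assay, at which 2 of the 3 values shown sit, and by one true number.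

Compound 4 (`COc1ccc(-c2nc(CSc3ccc(F)cc3F)nc3ccsc23)cn1`) puts 2,4-difluorophenyl in place of 2,3-dichlorophenyl on a sulfur, a difference counted as 2,4-difluorophenyl in place of 2,3-dichlorophenyl on a sulfur (the rest of the structure of compound 2 stays as it is). Among the compounds with values here, no measured step touches the group on the sulfur. Within the data shown here, the only measured step, an at least 1.2-fold lower number from compound 1 to compound 3 (0.09 log units; that floor lies within the scatter) on an aromatic carbon, stays within the scatter and is the sole guide to size, so no step beyond the scatter is expected for compound 4 in this assay and no direction can be favoured. The estimated step is a number no higher from compound 2 to compound 4 (the limit leaves the size open) and no larger. For compound 4 the estimate is 50000 nM within an expected range of 25000 nM to 90000 nM and the reading may well come back as a limit only.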

Compound 4, half-maximal cytotoxic concentration: > 50000 nM
Compound 4 was reported as a limit; the forecaster's own chance of this, stated with the estimate: 65%; the middle value sits exactly at the limit.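

In this assay compound 2 and compound 4 both stand only as limits of the assay, not as numbers, so no step between them can be read: the limit of > 50000 nM in this assay, at which 3 of the 4 values shown sit.

The compounds shown leave open how far 2,4-difluorophenyl and 2,3-dichlorophenyl on a sulfur differ in half-maximal cytotoxic concentration, and at what concentration either compound would reach it.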